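The source may hold more compounds than are shown below. What is called first, only, known or untested is meant among the compounds shown, and "the series" means these compounds.

Compound 1 `CCCCOc1ccc(-c2nc3ncccn3c2NC(C)(C)CC(C)(C)C)cc1`: 29000 nM
Compound 2 `CCCCOc1ccc(-c2nc3ncccn3c2N)cc1`: > 100000 nM (a limit of the assay)

In a toxicity assay on A549 cells (Homo sapiens) for cytotoxicity, read by luminescence and CellTiter-Glo, with a stated time of 48 h (a lower number here means that less compound is tolerated, a higher number that more compound is tolerated), compound 2 sits at > 100000 nM, which is a limit rather than a number (the limit of > 100000 nM in this assay, at which 1 of the 2 values shown sits). Compound 3 `CCCCOc1ccc(-c2nc3ncccn3c2NCc2ccco2)cc1` differs from compound 2 by (furan-2-yl)methyl in place of hydrogen on a nitrogen on an aromatic ring. Among the compounds with values here, the one measured step at this nitrogen, an at least 3.4-fold higher number from compound 1 to compound 2 (0.53 log units; beyond the scatter), went the other way: removing the alkyl group raised the number. Putting a substituent back on the same nitrogen is therefore expected to lower it, an at least 2.0-fold lower number from compound 2 to compound 3 (0.30 log units; that floor lies within the scatter). Compound 3 is estimated at 50000 nM, with a range from 15000 nM to 150000 nM.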

Compound 3, half-maximal cytotoxic concentration: 78000 nM
The estimate for compound 3 lay 1.6-fold (0.19 log units) below the measured number; the range from low to high includes it.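

In this assay the kind of group on this nitrogen counts, not only its presence: (furan-2-yl)methyl in place of 1,1,3,3-tetramethylbutyl gives a 2.7-fold higher number from compound 1 to compound 3 (0.43 log units; beyond the scatter). Placing (furan-2-yl)methyl where hydrogen stood gives an at least 1.2-fold lower number from compound 2 to compound 3 (0.10 log units; that floor lies within the scatter), so this group need not lower the number clearly. Compound 2 holds a limit, not a number: the limit of > 100000 nM in this assay, at which 1 of the 3 values shown sits.

From the compounds shown here alone, what a methyl, a cyclohexyl or a benzyl group on this nitrogen would give stays open. So does whether the furan ring itself matters, which a phenyl ring in its place could show.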